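A few compounds are considered here, and "the series" means these few. Any claim that something is new, unique, unknown or untested is made for them only; others in the source may bear on it.

Working notes on the series. Compound 1 `CC#CCn1c(N2CCC[C@@H](N)C2)cc(=O)n(Cc2ccc(Cl)c(C(=O)O)c2)c1=O` carries the shared core with a 3-carboxy-4-chlorophenyl arm. In an assay on isolated protein for inhibition of Dipeptidyl peptidase 9 (Homo sapiens), read by fluorescence, with stated times of 15 min and 20 min (a higher number here means a weaker inhibitor, a lower number a stronger inhibitor), compound 1 gives > 100 nM, which is a limit of the assay and not a number. Compound 2 `CC#CCn1c(N2CCC[C@@H](N)C2)cc(=O)n(Cc2cccc(C(=O)OC)c2Br)c1=O` gives > 100 nM in this assay, likewise a limit. Compound 3 `CC#CCn1c(N2CCC[C@@H](N)C2)cc(=O)n(Cc2ccc(Cl)c(C(=O)OC)c2)c1=O` gives > 100 nM in this assay, also a limit. For the measured compounds named here, the one single-point step measured so far, a step that the two limits leave unreadable from compound 1 to compound 3, methyl in place of hydrogen on an oxygen next to a carbonyl group, cannot be read in size because both of its ends sit at the limit of > 100 nM in this assay, at which 3 of the 3 values shown sit. Compound 1 therefore stands only at a limit, with no number of its own, and the two other values shown are limits as well.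

Compound 4 `CC#CCn1c(N2CCC[C@@H](N)C2)cc(=O)n(Cc2ccc(Br)c(C(=O)O)c2)c1=O` differs from compound 1 by bromo in place of chloro on an aromatic carbon. Going by the values given here, no measured step touches a halogen exchange; compound 2 and compound 3 differ from each other in more than one place, so their values show only that both sit at the limit. With nothing in the series pointing away from the limit, compound 4 is expected to sit there too, the estimated step that the limit leaves unreadable from compound 1 to compound 4 being none beyond the scatter. The estimate for compound 4 in this assay is 300 nM, in a range from 100 nM to 3000 nM.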

Compound 4, half-maximal inhibitory concentration: > 100 nM
Compound 4: a limit, no number; the forecaster's own chance of this, stated with the estimate: 85%; the middle value lies beyond the limit too.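

No new step can be read from compound 1 to compound 4, bromo in place of chloro on an aromatic carbon, because both ends sit at a limit and not at a number: the limit of > 100 nM in this assay, at which 4 of the 4 values shown sit.

The compounds shown leave open how any of these four compounds stands in this assay beyond that limit, and whether the halogen exchange changes anything.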